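Swapping a Thiazole for a Pyrrole on a Shared Core

The source may hold more compounds than are shown below. What is called first, only, known or untested is meant among the compounds shown, and "the series" means these compounds.

Compound 1, `OC[C@H]1O[C@@H](n2cc(F)c3c(-c4cccs4)ncnc32)[C@H](O)[C@@H]1O`: in a functional assay on CCRF-CEM cells (Homo sapiens) for cytotoxicity, read by XTT assay, with a stated time of 3 days (a higher number here means a weaker inhibitor, a lower number a stronger inhibitor), compound 1 gives 270 nM.
Compound 2, `OC[C@H]1O[C@@H](n2cc(F)c3c(-c4nccs4)ncnc32)[C@H](O)[C@@H]1O`: compound 2 gives 550 nM.
Compound 3, `OC[C@H]1O[C@@H](n2cc(F)c3c(-c4ccsc4)ncnc32)[C@H](O)[C@@H]1O`: compound 3 gives 560 nM.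

Among these three, compound 2 holds the second highest number, alongside compound 3 and apart from compound 1, which has the lowest. Compound 4, `OC[C@H]1O[C@@H](n2cc(F)c3c(-c4cc[nH]c4)ncnc32)[C@H](O)[C@@H]1O`, is not yet measured and differs from compound 2 in one place: 1H-pyrrol-3-yl in place of 1,3-thiazol-2-yl on an aromatic carbon. Among the compounds with values here, no measured step involves a 1H-pyrrol-3-yl group. The existing steps each swap one five-membered aromatic ring for another: a 2.0-fold higher number from compound 1 to compound 2 (0.31 log units; beyond the scatter), a 2.1-fold higher number from compound 1 to compound 3 (0.32 log units; beyond the scatter), and a 1.0-fold higher number from compound 2 to compound 3 (0.01 log units; within the scatter). Such swaps moved the number modestly or not at all, so a similar outcome is expected here: a 1.3-fold higher number from compound 2 to compound 4 (0.10 log units; within the scatter). Compound 4 is therefore estimated at 700 nM, with a range from 300 nM to 1600 nM.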

Compound 4, half-maximal inhibitory concentration: 930 nM
For compound 4 the middle estimate is 1.3-fold (0.12 log units) below the measured one; the measured number falls inside the stated range.
By their numbers in this assay, from the lowest: compound 1; then compounds 2, 3 and 4 (each within the scatter of the next).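

In this assay the 1H-pyrrol-3-yl ring, which carries a hydrogen-bond donor that 1,3-thiazol-2-yl lacks, stays within the scatter of two earlier rings (a 1.7-fold higher number from compound 2 to compound 4 (0.23 log units; within the scatter); a 1.7-fold higher number from compound 3 to compound 4 (0.22 log units; within the scatter)). Only the comparison with thiophen-2-yl goes beyond the scatter (a 3.4-fold higher number from compound 1 to compound 4 (0.54 log units; beyond the scatter)), so this position has now tolerated a donor-bearing five-membered ring with a modest difference at most. Nothing available explains these differences. From the compounds shown here alone, whether an amine, a methoxy group or a six-membered phenyl ring on this aromatic carbon would shift the number further remains open.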